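Urea nitrogen substituent: cyclopropyl to methyl

The source may report more compounds than this note shows. Statements on the series, on what has been measured and on what is new or still open speak of the compounds shown alone.

Measured so far:
- compound 1 `CCCNC(=O)N[C@H]1CCN(c2cccc3c2CCO3)C1` gives 17.7 nM in an assay on NIH3T3 cells for binding affinity to melatonin receptor type 1A (Homo sapiens); on this read-out higher numbers stand for weaker inhibition and lower numbers for stronger inhibition
- compound 2 `O=C(NC1CC1)N[C@H]1CCN(c2cccc3c2CCO3)C1` gives 21 nM in this assay
- compound 3 `O=C(NC1CC1)N[C@@H]1CCN(c2cccc3c2CCO3)C1` gives 6.6 nM in this assay

Compound 2 holds the highest number of the three in this assay. Its closest neighbour on the numbers is reached by a 1.2-fold higher number from compound 1 to compound 2 (0.07 log units; within the scatter); the furthest lies at a 3.2-fold lower number from compound 2 to compound 3 (0.50 log units; beyond the scatter), a difference that rests on the fact that compounds 2 and 3 differ only in the configuration as drawn and nothing else, so it says nothing about the substituent on the urea nitrogen.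

Compound 4 `CNC(=O)N[C@H]1CCN(c2cccc3c2CCO3)C1` is the next member, obtained from compound 2 by the change (methyl in place of cyclopropyl on an amide-type nitrogen). For the measured compounds named here, only one measured step bears on this kind of swap on the amide-type nitrogen: a 1.2-fold higher number from compound 1 to compound 2 (0.07 log units; within the scatter), where propyl and cyclopropyl gave numbers within the scatter of each other. The step from compound 2 to compound 3 concerns configuration alone and is set aside here. With a single relevant comparison, and that one flat, the expectation for compound 4 in this assay is a step of no more than the usual scatter, direction uncertain, so a 1.2-fold higher number from compound 2 to compound 4 (0.08 log units; within the scatter) is what the estimate amounts to. Compound 4 is therefore expected to give about 25 nM in this assay, within a range from 10 nM to 60 nM.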

Compound 4, inhibition constant: 0.9 nM
Compound 4: the middle estimate sits 28-fold (1.44 log units) above what was measured, and the stated range ends above it.
By their numbers in this assay, from the lowest: compound 4; then compound 3; then compounds 1 and 2 (each within the scatter of the next).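

In this assay the substituent on the amide-type nitrogen had looked flat, with a 1.2-fold higher number from compound 1 to compound 2 (0.07 log units; within the scatter), but methyl in place of cyclopropyl gives a 23-fold lower number from compound 2 to compound 4 (1.37 log units; beyond the scatter), and the comparison with the propyl compound reads the same way, with a 20-fold lower number from compound 1 to compound 4 (1.29 log units; beyond the scatter). The position therefore does respond to this substituent, and the response is large: among the three groups shown, propyl and cyclopropyl stay within the scatter of each other, while methyl stands well apart from both on the side of stronger inhibition. Nothing at hand accounts for the size of this step, as the only supporting observation concerns configuration and not the substituent.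

Open, going by these compounds, is where along the series the change sets in: ethyl on the same nitrogen would show whether the number stays close to that of the methyl compound or to that of the propyl compound, and the plain unsubstituted amino group would show whether the trend continues past methyl. Also open, on these data alone, is whether methyl brings a similar step in the configuration drawn for compound 3, which with cyclopropyl gave a 3.2-fold lower number from compound 2 to compound 3 (0.50 log units; beyond the scatter), or whether the two changes fail to add up.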